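A few compounds are considered here, and "the series" means these few. Any claim that something is new, unique, unknown or untested is made for them only; others in the source may bear on it.

Of the compounds shown here, three have been measured in a functional assay on NCI-H1975 cells (Homo sapiens) for cytotoxicity, read by MTT assay, with a stated time of 72 h; a higher number here means a weaker inhibitor, a lower number a stronger inhibitor.

Compound 1 `O=C(N/N=C/c1ccc(Br)cc1)N1CCc2ncnc(Nc3ccc(F)c(Cl)c3)c2C1`: > 200000 nM.
Compound 2 `Cc1ccc(/C=N/NC(=O)N2CCc3ncnc(Nc4ccc(F)c(Cl)c4)c3C2)cc1C`: 6830 nM.
Compound 3 `O=C(N/N=C/c1ccc(F)cc1)N1CCc2ncnc(Nc3ccc(F)c(Cl)c3)c2C1`: 64500 nM.

For compound 1 the reading is a limit and not a number: the limit of > 200000 nM in this assay, at which 1 of the 3 values shown sits. Compound 4 `N#Cc1ccc(/C=N/NC(=O)N2CCc3ncnc(Nc4ccc(F)c(Cl)c4)c3C2)cc1` has not yet been measured in this assay. It carries cyano in place of bromo on an aromatic carbon, (cyano in place of bromo on an aromatic carbon).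

The closest measured change is fluoro in place of bromo at that same place, which gave an at least 3.1-fold lower number from compound 1 to compound 3 (0.49 log units; beyond the scatter). Replacing the whole 4-bromophenyl with 3,4-dimethylphenyl gave an at least 29-fold lower number from compound 1 to compound 2 (1.46 log units; beyond the scatter). The two replacements do not land together, as a 9.4-fold higher number from compound 2 to compound 3 (0.98 log units; beyond the scatter) shows. Both went towards a lower number, so the same direction is expected for compound 4, with a size nearer to the fluoro change, since that too alters only the group on this one carbon.

The expected step is an at least 4.0-fold lower number from compound 1 to compound 4 (0.60 log units; beyond the scatter). Compound 4 is estimated at 50000 nM, with an expected range of 10000 nM to 200000 nM.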

Compound 4, half-maximal inhibitory concentration: 67500 nM
For compound 4 the middle estimate is 1.4-fold (0.13 log units) below the measured one; measured number inside the range.
By their numbers in this assay, from the lowest: compound 2; then compounds 3 and 4 (each within the scatter of the next). At a limit, above all of these: compound 1.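

Cyano on the aromatic carbon that carried bromo is a second small replacement that moves the same way as fluoro, an at least 2.9-fold lower number from compound 1 to compound 4 (0.47 log units; beyond the scatter) in this assay, and that size is only a bound because compound 1 is held by a limit: the limit of > 200000 nM in this assay, at which 1 of the 4 values shown sits. Against fluoro, cyano brings no difference that can be told, a 1.0-fold higher number from compound 3 to compound 4 (0.02 log units; within the scatter), so these two groups read alike on this carbon even though cyano adds a heavy atom and a hydrogen-bond acceptor. The 4-cyanophenyl stays well apart from the 3,4-dimethylphenyl, a 9.9-fold higher number from compound 2 to compound 4 (0.99 log units; beyond the scatter), much as the 4-fluorophenyl does.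

The compounds shown leave open how a 4-methylphenyl or a 3-methylphenyl would read here. They therefore cannot tell whether one methyl alone would account for the standing of compound 2, or whether both are required.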